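The source may report more compounds than this note shows. Statements on the series, on what has been measured and on what is new or still open speak of the compounds shown alone.

Compound 1 `CS(=O)(=O)Oc1c(C(=O)NCc2ccc(F)cc2)nc(Br)c2cccnc12` and compound 2 `O=CNCCCCCCNc1nc(C(=O)NCc2ccc(F)cc2)c(O)c2ncccc12` carry the same core and amide, differing in what sits on the ring beyond it. In a functional assay on HCT-116 cells (Homo sapiens) for cytotoxicity, read by MTT assay, with a stated time of 72 h (on this read-out lower numbers stand for stronger inhibition and higher numbers for weaker inhibition), compound 1 reaches only the limit of the method, > 20000 nM, and no number is known for it. Compound 1 therefore stands at the limit of > 20000 nM in this assay, at which 1 of the 2 values shown sits. In this assay compound 2 gives 6000 nM, a measured value rather than a limit. Among the measured compounds shown here, no pair of measured compounds differs in a single place, so no measured step is available.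

Compound 3 `Cc1ccc(S(=O)(=O)Oc2c(C(=O)NCc3ccc(F)cc3)nc(Br)c3cccnc23)cc1` has not yet been measured. It differs from compound 1 by 4-methylphenyl in place of methyl on a sulfonyl sulfur. With compound 1 sitting at the limit of > 20000 nM in this assay, at which 1 of the 2 values shown sits, the step of a number no higher from compound 1 to compound 3 (the limit leaves the size open) is expected to be none beyond the scatter, in no clear direction. Compound 3 is accordingly estimated at 20000 nM in this assay, with a range from 6000 nM to 60000 nM, and a further limit reading would not surprise.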

Compound 3, half-maximal inhibitory concentration: > 20000 nM
Compound 3: no number, only a limit (the forecaster's own chance of this, stated with the estimate: 65%); the middle value sits exactly at the limit.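

Among the compounds shown here, compound 1 and compound 3 both end at a limit in this assay rather than at a number, so no step between them can be read: the limit of > 20000 nM in this assay, at which 2 of the 3 values shown sit. The compounds shown leave open whether 4-methylphenyl in place of methyl on a sulfonyl sulfur changes the result in this assay at all.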